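Carbonyl-side aryl exchange: notes toward compound 3

The source may report more compounds than this note shows. Statements on the series, on what has been measured and on what is new or still open speak of the compounds shown alone.

Compound 2 `COc1cc(-c2cc(/C=C/C(=O)c3ccc(Cl)c(Cl)c3)[nH]n2)cc(OC)c1OC` stands highest of the two numbers in hand: in a functional assay on M14 cells (Homo sapiens) for cytotoxicity, read by sulforhodamine B assay, with a stated time of 48 h, tested at 10 uM (on this read-out lower numbers stand for a stronger effect and higher numbers for a weaker effect at the one concentration tested), compound 2 gives 61%. The nearest measured neighbour, compound 1 `COc1ccc(-c2cc(/C=C/C(=O)c3ccc(N)cc3)[nH]n2)cc1`, lies far lower, since compound 1 gives -24% in this assay, a gap well beyond the usual scatter. Among the measured compounds shown here, the two differ in more than one place, so their values show only that compound 1 has the stronger effect and compound 2 the weaker.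

Compound 3 `COc1ccc(C(=O)/C=C/c2cc(-c3cc(OC)c(OC)c(OC)c3)n[nH]2)cc1` is next to be measured in this assay. It departs from compound 2 by a single change (4-methoxyphenyl in place of 3,4-dichlorophenyl on a carbonyl carbon). For the measured compounds named here, no step between measured compounds covers this exchange, so the expectation rests only on the two values above. A downward step from compound 2 is expected, with wide uncertainty, of the size a number 31 percentage points lower from compound 2 to compound 3 (beyond the scatter). Compound 3 is estimated at 30%, within -20% to 75%.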

Compound 3, a percentage reported as activity, at one concentration (the size of the read-out at that concentration, not a potency): -44%
Beside the measured number, compound 3's estimate is 74 percentage points above it; measured number outside the range, below it.
By their numbers in this assay, from the lowest: compound 3; then compound 1; then compound 2.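

With the rest of the structure held, 4-methoxyphenyl in place of 3,4-dichlorophenyl on a carbonyl carbon gives, in this assay, a number 105 percentage points lower from compound 2 to compound 3 (beyond the scatter). Among the compounds shown here, this is the first single-place step, and it shows that this one group can decide the read-out on its own, even though both groups hold 8 heavy atoms and one six-membered aromatic ring of carbon only. Nothing in hand accounts for the size of the step.

Still open, going by these compounds, is whether the step follows from the entry of methoxy or from the loss of chlorine, which a 4-hydroxyphenyl or 4-fluorophenyl group on the same carbonyl carbon would help to separate. Also open, on these data alone, is whether the exchange gives a step of similar size when the rest of the structure differs.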